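The source may report more compounds than this note shows. Statements on the series, on what has been measured and on what is new or still open speak of the compounds shown alone.

In a functional assay on SW480 cells (Homo sapiens) for antiproliferative activity, read by MTT assay, with a stated time of 48 h (on this read-out higher numbers stand for weaker inhibition and lower numbers for stronger inhibition), compound 2 (`CCCCCCCC(CCO)n1cnc2c(NC)ncnc21`) holds the higher of the two numbers at 15300 nM, while compound 1 (`CCCCCCCC(CCO)n1cnc2c(Cl)ncnc21`) gives 3630 nM. Compound 3 (`CCCCCCCC(CCO)n1cnc2c(N)ncnc21`) is the next entry: hydrogen in place of methyl on a nitrogen on an aromatic ring. For the measured compounds named here, only one measured step bears on it, and only loosely: a 4.2-fold higher number from compound 1 to compound 2 (0.62 log units; beyond the scatter), modest, with methylamino replacing chloro and no direct reading on the methyl. No step beyond the scatter is expected, and the estimate is a 1.2-fold lower number from compound 2 to compound 3 (0.07 log units; within the scatter), slightly downward. For compound 3 the estimated value is 13000 nM, with a range of 5500 nM to 30000 nM.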

Compound 3, half-maximal inhibitory concentration: > 50000 nM
Compound 3: a limit, no number; the forecaster's own chance of this, stated with the estimate: 10%; at least 3.8-fold (0.58 log units) between middle value and limit.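

In this assay compound 3 gives a limit of the assay, not a number: the limit of > 50000 nM in this assay, at which 1 of the 3 values shown sits.
Taking the methyl off the nitrogen does not recover activity: the read-out moves further the same way as the earlier change from chloro, with an at least 3.2-fold higher number from compound 2 to compound 3 (0.51 log units; beyond the scatter) on this change. The amino group also widens the gap to the chloro group, with an at least 13-fold higher number from compound 1 to compound 3 (1.13 log units; beyond the scatter) at this position, so compound 1 keeps the lowest number of the three.

On these data alone, how far past the limit compound 3 lies stays open. Also open, as far as these compounds go, is how dimethylamino, methoxy or bromo would read on this aromatic carbon.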